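Stilbene series: geometry step at the stilbene double bond

The compounds below may be only part of what the source reports. "The series", "measured", "known", "first", "only" and "open" are said of these compounds alone.

Measured so far:
compound 1 `CC1(C)CCC(C)(C)c2cc(/C=C/c3cccc(N)c3)ccc21` — 20000 nM
compound 2 `COc1ccc(/C=C\c2ccc3c(c2)C(C)(C)CCC3(C)C)cc1` — 50000 nM

In a functional assay on HL-60 cells (Homo sapiens) for cytotoxicity (on this read-out higher numbers stand for weaker inhibition and lower numbers for stronger inhibition), compound 1 gives 20000 nM and compound 2 gives 50000 nM, so compound 2 stands with the highest number of the two, beyond the scatter from compound 1.

The next step leads to compound 3 `COc1ccc(/C=C/c2ccc3c(c2)C(C)(C)CCC3(C)C)cc1`: the two compounds have the same atoms and bonds and differ only in configuration as drawn: 1 of 1 stereo elements differ; a double bond is drawn Z in compound 2 and E in compound 3. Within the data shown here, no measured pair shows such a change, so its size is open. A move to a lower number in this assay is expected, on the order of a 5.0-fold lower number from compound 2 to compound 3 (0.70 log units; beyond the scatter), but with wide uncertainty. For compound 3 the estimate in this assay is 10000 nM, between 2000 nM and 40000 nM.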

Compound 3, half-maximal inhibitory concentration: 50000 nM
For compound 3 the middle estimate is 5.0-fold (0.70 log units) below the measured one; the measured number lies above the stated range.
By their numbers in this assay, from the lowest: compound 1; then compounds 2 and 3 (each within the scatter of the next).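

In this assay, turning the double bond from Z to E gives no change at the digits printed from compound 2 to compound 3 (within the scatter). With the E double bond held, 4-methoxyphenyl in place of 3-aminophenyl gives a 2.5-fold higher number from compound 1 to compound 3 (0.40 log units; beyond the scatter), so this aryl change can now be read apart from any change of geometry. The first of these steps reads as a change of geometry alone: the fact that compounds 2 and 3 differ only in the configuration as drawn.

From the compounds shown here alone, whether geometry also makes no difference with 3-aminophenyl on the chain remains open. So does the effect of a carboxylic acid on that ring in place of the methoxy group.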